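Chloro for methoxy on the acetamide chain of compound 1

The compounds below may be only part of what the source reports. "The series", "measured", "known", "first", "only" and "open" are said of these compounds alone.

Working notes on a small set of trimethoxyanilides. In a functional assay on HCT-116 cells (Homo sapiens) for inhibition, read by MTT assay, with a stated time of 48 h (a higher number here means a weaker inhibitor, a lower number a stronger inhibitor), compound 1, `COCC(=O)N(Cc1ccc(OC)c(O)c1)c1cc(OC)c(OC)c(OC)c1`, gives 230 nM, the lowest of the two numbers recorded here. Compound 3, `C/C=C/C(=O)N(Cc1ccc(OC)c(Br)c1)c1cc(OC)c(OC)c(OC)c1`, gives 2800 nM in this assay, a gap beyond the scatter that separates it from compound 1. Compound 2, `COc1cc(NCc2ccc(Cl)cc2)cc(OC)c1OC`, is the secondary amine without an acyl group; in this assay compound 2 reaches only the limit, > 80000 nM. That value is the limit of > 80000 nM in this assay, at which 1 of the 3 values shown sits.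

The unmeasured compound 4, `COc1ccc(CN(C(=O)CCl)c2cc(OC)c(OC)c(OC)c2)cc1O`, keeps the core and the benzyl substitution of compound 1 and alters only the acyl chain: chloro in place of methoxy on a saturated chain carbon bound to a carbonyl carbon. Within the data shown here, no measured pair in this set shares that single change, so there is no direct precedent to point to. The compounds that do carry an acyl group both return a number, and compound 1 sits at the stronger end of them.

The expected step is a 1.5-fold lower number from compound 1 to compound 4 (0.19 log units; within the scatter), a small shift toward a lower number, not clearly beyond the scatter. Compound 4 is therefore estimated at 150 nM in this assay, with a range from 40 nM to 800 nM.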

Compound 4, half-maximal inhibitory concentration: 250 nM
Estimate against measurement, compound 4: 1.7-fold (0.22 log units) below, and the stated range covers the measured number.
By their numbers in this assay, from the lowest: compounds 1 and 4 (each within the scatter of the next); then compound 3. At a limit, above all of these: compound 2.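

In this assay, among these compounds, the position on a saturated chain carbon bound to a carbonyl carbon now has its first direct reading, from the only pair in this set that differs in one place: a 1.1-fold higher number from compound 1 to compound 4 (0.04 log units; within the scatter). Methoxy and chloro therefore cannot be told apart at this position in this assay, although the two groups differ in their counts of heavy atoms and hydrogen-bond acceptors, so the change from methoxymethyl to chloromethyl on the acyl chain has no readable effect on the number with the benzyl substitution of compound 1 held fixed. No measurement in this set gives a reason why the two groups read alike.

Among the compounds shown here, what an amine, a carboxylic acid or a longer chain would do on this same carbon remains open, so the single pair fixes neither how much variation the position tolerates nor which features of the chain matter. Also open, as far as these compounds go, is whether chloro and methoxy would still read alike with a different benzyl substitution, such as that of compound 3.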